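Swapping the ring on the hydroxylated side chain

The compounds below may be only part of what the source reports. "The series", "measured", "known", "first", "only" and "open" are said of these compounds alone.

In a functional assay on MCF7 cells (Homo sapiens) for inhibition, read by MTT assay, with a stated time of 72 h (on this read-out higher numbers stand for weaker inhibition and lower numbers for stronger inhibition), compound 1 `Nc1ncn(C/C=C2\OC(=O)C(OCc3ccccc3)=C2OCc2ccccc2)c(=O)n1` gives 3490 nM, and compound 2 `Nc1ccn(C[C@H](O)[C@H]2OC(=O)C(OCc3ccccc3)=C2OCc2ccccc2)c(=O)n1` gives 7340 nM. Compound 3 `O=C1O[C@H]([C@@H](O)Cn2c(=O)[nH]c(=O)[nH]c2=O)C(OCc2ccccc2)=C1OCc1ccccc1` reaches only the limit of > 100000 nM in this assay, a limit and not a number. Among the three values shown, compound 3 thus sits at the weak end, marked by the limit of > 100000 nM in this assay, at which 1 of the 3 values shown sits. Within the data shown here, the step of an at least 13-fold higher number from compound 2 to compound 3 (1.13 log units; beyond the scatter) is the one measured change that bears on compound 4 `Nc1ncn(C[C@H](O)[C@H]2OC(=O)C(OCc3ccccc3)=C2OCc2ccccc2)c(=O)n1`, which differs from compound 3 by a group of 8 heavy atoms (3 carbon, 4 nitrogen, 1 oxygen; one six-membered aromatic ring with 3 hetero atoms) in place of a group of 9 heavy atoms (3 carbon, 3 nitrogen, 3 oxygen; one six-membered aromatic ring with 3 hetero atoms), on a saturated chain carbon, two bonds along the chain from an oxygen on a saturated carbon and a saturated ring carbon. Among the measured compounds shown here, since that change runs opposite to the one that weakened compound 3, a large fall in the number is expected for compound 4, roughly an at least 16-fold lower number from compound 3 to compound 4 (1.22 log units; beyond the scatter), and compound 4 is estimated at 6000 nM, between 2000 nM and 25000 nM.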

Compound 4, half-maximal inhibitory concentration: 73800 nM
Compound 4: the middle estimate sits 12-fold (1.09 log units) below what was measured; the measured number lies above the stated range.
By their numbers in this assay, from the lowest: compound 1; then compound 2; then compound 4. At a limit, above all of these: compound 3.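

On this saturated chain carbon, the ring of compound 4 gives a 10-fold higher number from compound 2 to compound 4 (1.00 log units; beyond the scatter), so the weakening seen on leaving the ring of compound 2 is not confined to compound 3. The other comparison reads an at least 1.3-fold lower number from compound 3 to compound 4 (0.13 log units; that floor lies within the scatter), and this floor alone does not separate the two rings. Compound 3 itself remains a limit and not a number: the limit of > 100000 nM in this assay, at which 1 of the 4 values shown sits.

The compounds shown leave open how a fluorine or a methyl group on the ring of compound 2 would read, and whether a longer chain would change these steps.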